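The source may hold more compounds than are shown below. What is called first, only, known or untested is meant among the compounds shown, and "the series" means these compounds.

Measured compounds:
Compound 1 `COc1ccc(CNc2cc(OC)c(OC)c(OC)c2)cc1[N+](=O)[O-]`: 16800 nM
Compound 2 `COc1cc(NCc2ccc(Cl)cc2)cc(OC)c1OC`: > 80000 nM

The read-out for both is a functional assay on KYSE-450 cells (Homo sapiens) for inhibition, read by MTT assay, with a stated time of 48 h; on this read-out lower numbers stand for stronger inhibition and higher numbers for weaker inhibition. Within the data shown here, compound 1 holds the only actual number, 16800 nM. The entry for compound 2 is a limit of the assay, as the limit of > 80000 nM in this assay, at which 1 of the 2 values shown sits, records. Compound 3 `COc1ccc(CNc2cc(OC)c(OC)c(OC)c2)cc1F` keeps the core of compound 1 but carries fluoro in place of nitro on an aromatic carbon, ortho to a methoxy group: fluoro in place of nitro on an aromatic carbon. Among the measured compounds shown here, no measured single-place step is available to guide this change, so only a modest shift towards weaker inhibition in this assay is expected, as a 1.5-fold higher number from compound 1 to compound 3 (0.17 log units; within the scatter). For compound 3 the estimated value is 25000 nM, with an expected range of 9000 nM to 70000 nM.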

Compound 3, half-maximal inhibitory concentration: 46200 nM
Beside the measured number, compound 3's estimate is 1.8-fold (0.27 log units) below it; the range from low to high includes it.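

The position ortho to a methoxy group now has its first measured single-place step in this assay and it is not indifferent to the group it carries: fluoro in place of nitro gives a 2.8-fold higher number from compound 1 to compound 3 (0.44 log units; beyond the scatter) and so weakens inhibition modestly, with the nitro form of the core the stronger of the pair. Nothing measured here explains this shift.

Only nitro and fluoro can be compared at this position. Going by these compounds, how an amine, a nitrile or a carboxylic acid would read there remains open, as does whether any would give stronger inhibition than compound 1.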